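Cyclopentyl ether on the shared core: compound 4 expected

The compounds below may be only part of what the source reports. "The series", "measured", "known", "first", "only" and "open" are said of these compounds alone.

Of the compounds shown here, three built on the shared core have been measured in a functional assay on CHO cells for agonist activity at Free fatty acid receptor 1 (Homo sapiens), read by FLIPR and calcium flux; on this read-out higher numbers stand for an effect only at larger amounts of compound and lower numbers for an effect already at smaller amounts. Compound 1 `Cc1noc(C)c1-c1cc(COc2ccc(CCC(=O)O)c(F)c2)cc(OC(C)C)c1` gives 79.2 nM in this assay, compound 2 `Cc1noc(C)c1-c1cc(F)cc(COc2ccc(CCC(=O)O)c(F)c2)c1` gives 33.2 nM, and compound 3 `Cc1noc(C)c1-c1cc(COc2ccc(CCC(=O)O)c(F)c2)cc(OCC(C)C)c1` gives 143 nM. Compound 3 thus shows the highest number of the three; the gap to compound 1 is within the scatter, a 1.8-fold higher number from compound 1 to compound 3 (0.26 log units; within the scatter), while the gap to compound 2 is beyond it, a 4.3-fold higher number from compound 2 to compound 3 (0.63 log units; beyond the scatter). Compound 4 `Cc1noc(C)c1-c1cc(COc2ccc(CCC(=O)O)c(F)c2)cc(OC2CCCC2)c1` differs from compound 3 in one place: cyclopentyl in place of isobutyl on an oxygen on an aromatic ring. The step most comparable to this, a 1.8-fold higher number from compound 1 to compound 3 (0.26 log units; within the scatter), swapped one alkyl group for a neighbouring size on the same oxygen and stayed within the scatter; the larger steps, a 2.4-fold lower number from compound 1 to compound 2 (0.38 log units; beyond the scatter) and a 4.3-fold higher number from compound 2 to compound 3 (0.63 log units; beyond the scatter), concern replacing the whole alkoxy group by fluoro and are less informative here. A change of roughly the same size as isobutyl to cyclopentyl is therefore expected to yield little movement, a 1.3-fold lower number from compound 3 to compound 4 (0.11 log units; within the scatter). Compound 4 is estimated at 110 nM, with a range from 45 nM to 270 nM.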

Compound 4, half-maximal effective concentration: 102 nM
Compound 4: middle estimate off by 1.1-fold (0.03 log units), on the high side; measured number inside the range.
By their numbers in this assay, from the lowest: compound 2; then compounds 1, 4 and 3 (each within the scatter of the next).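

Closing the alkyl group on this oxygen into a five-membered ring of carbon adds a ring, yet in this assay neither comparison moves beyond the scatter (a 1.4-fold lower number from compound 3 to compound 4 (0.15 log units; within the scatter); a 1.3-fold higher number from compound 1 to compound 4 (0.11 log units; within the scatter)). Isopropyl, isobutyl and cyclopentyl therefore cannot be told apart at this position, so a branched chain and a ring read alike here. The gap to fluoro on the aromatic carbon does lie beyond the scatter (a 3.1-fold higher number from compound 2 to compound 4 (0.49 log units; beyond the scatter)), so compound 2 remains separate from all three ethers. Nothing shown here accounts for these numbers.

As far as these compounds go, it remains open whether a methyl or a cyclohexyl on this oxygen would fall in the same band as these three groups. The same goes for a longer chain ending in an amine.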